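Allyloxy to isopropoxy on the shared core

The compounds below may be only part of what the source reports. "The series", "measured", "known", "first", "only" and "open" are said of these compounds alone.

Compound 1 `C=CCOc1cc(C2=C(c3cc(OC)c(OC)c(OC)c3)C(=O)C(O)C2)ccc1OC` is the starting point for this step. In an ADME assay on ECV-304 cells (Homo sapiens) for cytotoxicity, read by MTT assay, with a stated time of 72 h (on this read-out lower numbers stand for stronger inhibition and higher numbers for weaker inhibition), compound 1 gives > 100 ug/mL as a limit of the assay and not a number. Compound 2 `COc1ccc(C2=C(c3cc(OC)c(OC)c(OC)c3)CC(O)C2=O)cc1[N+](=O)[O-]` gives > 100 ug/mL in this assay and is also reported only as a limit. The series therefore stands at the limit of > 100 ug/mL in this assay, at which 2 of the 2 values shown sit, and so far offers no numerical value.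

Compound 3 `COc1ccc(C2=C(c3cc(OC)c(OC)c(OC)c3)C(=O)C(O)C2)cc1OC(C)C` carries isopropyl in place of allyl on an oxygen on an aromatic ring, and the counted difference is isopropyl in place of allyl on an oxygen on an aromatic ring with the rest of the core unchanged. Among the compounds with values here, no measured pair isolates this change. In this assay no shift beyond the usual scatter is expected, and no direction is favoured. Within the data shown here, that expectation rests on compound 1 at > 100 ug/mL as a limit and on the single change. The estimated step that the limit leaves unreadable from compound 1 to compound 3 is expected to stay within the scatter, and another limit is the likeliest report. For compound 3 the expected value is 130 ug/mL with an estimated range from 60 ug/mL to 250 ug/mL on this read-out.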

Compound 3, half-maximal inhibitory concentration: > 100 ug/mL
Compound 3 was reported as a limit; the forecaster's own chance of this, stated with the estimate: 85%; the middle value lies beyond the limit too.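

Within the data shown here, compound 1 and compound 3 are both reported only as limits in this assay, so no step from allyloxy to isopropoxy can be read between them. The compounds shown leave open the size of that change and whether any compound on the shared core gives a numerical value in this assay: the limit of > 100 ug/mL in this assay, at which 3 of the 3 values shown sit.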